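A few compounds are considered here, and "the series" means these few. Any claim that something is new, unique, unknown or untested is made for them only; others in the source may bear on it.

Measured so far:
compound 1 `O=c1cc(-c2c[nH]c3ncccc23)nc(NC2CCCCC2)[nH]1`, 103 nM
compound 2 `O=c1cc(-c2c[nH]c3ncccc23)nc(NCc2ccccc2)[nH]1`, 122 nM
compound 3 `O=c1cc(-c2c[nH]c3ncccc23)nc(NC2CCOCC2)[nH]1`, 2460 nM

In a functional assay on HCT-116 cells (Homo sapiens) for cytotoxicity, with a stated time of 3 days (on this read-out lower numbers stand for an effect already at smaller amounts and higher numbers for an effect only at larger amounts of compound), compound 3 holds the highest number of the three: the steps of a 24-fold higher number from compound 1 to compound 3 (1.38 log units; beyond the scatter) and a 20-fold higher number from compound 2 to compound 3 (1.30 log units; beyond the scatter) are both large, while a 1.2-fold higher number from compound 1 to compound 2 (0.07 log units; within the scatter) is not. Compound 4 `COC1CCN(c2nc(-c3c[nH]c4ncccc34)cc(=O)[nH]2)CC1` differs from compound 3 by 4-methoxypiperidin-1-yl in place of (oxan-4-yl)amino on an aromatic carbon. Among the measured compounds shown here, no measured step exchanges the amino group itself; the three known steps only vary what hangs on its nitrogen, so they bear on this change only loosely. The shared oxygen-bearing ring gives some reason to expect a number near that of compound 3, with wide uncertainty. Compound 4 is therefore estimated at 3000 nM, between 700 nM and 13000 nM, a step of a 1.2-fold higher number from compound 3 to compound 4 (0.09 log units; within the scatter).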

Compound 4, half-maximal effective concentration: 520 nM
Compound 4: middle estimate off by 5.8-fold (0.76 log units), on the high side, and the stated range ends above it.
By their numbers in this assay, from the lowest: compounds 1 and 2 (each within the scatter of the next); then compound 4; then compound 3.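

In this assay, the step of a 4.7-fold lower number from compound 3 to compound 4 (0.67 log units; beyond the scatter) shows that this position, between two ring nitrogen atoms, accepts a group with no hydrogen-bond donor, and that an oxygen-bearing ring need not cost as much as compound 3 suggested. Even so, the steps of a 4.3-fold higher number from compound 2 to compound 4 (0.63 log units; beyond the scatter) and a 5.0-fold higher number from compound 1 to compound 4 (0.70 log units; beyond the scatter) leave 4-methoxypiperidin-1-yl short of benzylamino and cyclohexylamino. Nothing measured here accounts for these steps. Open remains whether plain piperidin-1-yl or morpholine would match this result, which would show what the methoxy group contributes. Also open, going by these compounds, is whether a methyl on the nitrogen of (oxan-4-yl)amino would give a similar shift.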